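From nitro to methoxy: one open number

The source may report more compounds than this note shows. Statements on the series, on what has been measured and on what is new or still open speak of the compounds shown alone.

Of the compounds shown here, three built on a shared core have been measured so far in a physicochemical assay, read by spectrophotometry, with a stated time of 30 min (on this read-out higher numbers stand for weaker inhibition and lower numbers for stronger inhibition), and their values are close together. There, compound 1 (`O=C(CCc1nc2ccccc2c(=O)[nH]1)N/N=C/c1ccc([N+](=O)[O-])cc1`) gives 328000000 nM as its half-maximal inhibitory concentration, and compound 3 (`O=C(CCCc1nc2ccccc2c(=O)[nH]1)N/N=C/c1ccc([N+](=O)[O-])cc1`) gives 316000000 nM as its own. These two lie within the usual scatter of each other, so they count as level. Compound 2 (`COc1cc(/C=N/NC(=O)CCCc2nc3ccccc3c(=O)[nH]2)cc(O)c1O`) gives 88000000 nM in this assay as its value, a lower number than compound 3 by more than the scatter.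

Compound 4 (`COc1ccc(/C=N/NC(=O)CCCc2nc3ccccc3c(=O)[nH]2)cc1`) has not been measured yet. It keeps all of compound 3 except for one group, with methoxy in place of nitro on an aromatic carbon, the change from 4-nitrophenyl to 4-methoxyphenyl. Within the data shown here, no measured pair shows this swap alone. Compound 2 also carries a methoxy group and stands at 88000000 nM in the same test, but it has other differences too, so it offers only a weak hint towards a lower number. The estimated step (a 1.6-fold lower number from compound 3 to compound 4 (0.20 log units; within the scatter)) is therefore small, points towards a lower number and is expected to stay within the scatter. Compound 4 is expected at 200000000 nM with an estimated range from 80000000 nM to 450000000 nM in this assay once it is measured.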

Compound 4, half-maximal inhibitory concentration: 247000000 nM
Compound 4: the middle estimate sits 1.2-fold (0.09 log units) below what was measured; the range from low to high includes it.
By their numbers in this assay, from the lowest: compound 2; then compounds 4, 3 and 1 (each within the scatter of the next).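

The swap of nitro for methoxy, para to a large group, can now be read on its own: in this assay it gives a 1.3-fold lower number from compound 3 to compound 4 (0.11 log units; within the scatter). At this position, then, two groups that differ in their atoms and in their counted hydrogen-bond acceptors leave the number level, and this single pair gives the methoxy group no shift beyond the scatter, so the earlier weak hint from compound 2, which differs from compound 3 in more than one place, finds no firm support here. No measurement is available that could explain why the two groups read alike.

As far as these compounds go, one pair cannot show how wide this flat stretch is, so it remains open whether an amine or a carboxylic acid on the same aromatic carbon would also stay level with compound 3 or would move the number beyond the scatter. Among these compounds, it is also open whether the change from 4-nitrophenyl to 4-methoxyphenyl would read the same on the chain of compound 1, where no such pair is available.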